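Hydroxy for methoxy on a weak phosphodiesterase series

A few compounds are considered here, and "the series" means these few. Any claim that something is new, unique, unknown or untested is made for them only; others in the source may bear on it.

Compound 1 `COCCCNc1ccnc2c1nc(-c1ccco1)n2C1CCCC1`: 90500 nM
Compound 2 `COCCNc1nccc2c1nc(-c1ccco1)n2C1CCCC1`: 192000 nM
Compound 3 `COCCCNc1nccc2c1nc(-c1ccco1)n2C1CCCC1`: 142000 nM

All three measured compounds share a core and differ only in the chain on the amino group. In an assay on isolated protein for inhibition of high affinity 3',5'-cyclic-AMP phosphodiesterase 7A (Homo sapiens), read by cAMP accumulation, with a stated time of 20 min (on this read-out higher numbers stand for weaker inhibition and lower numbers for stronger inhibition), compound 3 gives 142000 nM, the second highest of the three numbers; compound 2 sits nearest to it, and compound 1 furthest, both within the scatter. Going by the values given here, the one step between neighbours, a 1.4-fold lower number from compound 2 to compound 3 (0.13 log units; within the scatter), is a chain-length change and lies within the scatter as well.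

Compound 4 `OCCCNc1nccc2c1nc(-c1ccco1)n2C1CCCC1` is the next step from compound 3: hydrogen in place of methyl on an oxygen on a saturated carbon; cut one bond further out, the change reads methoxy to hydroxy. Among the compounds with values here, no measured step touches this oxygen substituent, so nothing gives a direction for it. Within the data shown here, the only step available, that from compound 2 to compound 3, was within the scatter, and the three values spread little, so compound 4 is expected to move by about a 1.1-fold higher number from compound 3 to compound 4 (0.02 log units; within the scatter) in this assay, that is by no step beyond the scatter. The estimated value for compound 4 is therefore 150000 nM, with a range from 50000 nM to 450000 nM.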

Compound 4, half-maximal inhibitory concentration: > 200000 nM
Compound 4: only a limit was reported; the forecaster's own chance of this, stated with the estimate: 30%; middle value at least 1.3-fold (0.12 log units) away from the limit.
By their numbers in this assay, from the lowest: compounds 1, 3 and 2 (each within the scatter of the next, the first and the last beyond it). At a limit, above all of these: compound 4.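

The reading for compound 4 in this assay is a limit and not a number: the limit of > 200000 nM in this assay, at which 1 of the 4 values shown sits.

Hydrogen in place of methyl on this oxygen, the first change made to this substituent among the compounds shown, gives an at least 1.4-fold higher number from compound 3 to compound 4 (0.14 log units; that floor lies within the scatter), and the comparison with the shorter chain gives an at least 1.0-fold higher number from compound 2 to compound 4 (0.01 log units; that floor lies within the scatter). Going by these compounds alone, neither floor establishes a real change, but the limit does show what the earlier compounds could not: methoxy to hydroxy on this chain brought no lower number.

As far as these compounds go, how far the true value of compound 4 lies past its limit stays open, so the full size of both steps is unknown. Also open, from the compounds shown here alone, is whether an amine or a carboxylic acid in place of the methoxy, or a longer chain, would give a lower number than these compounds do.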